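This account rests on a few compounds, and the source may have more. Where it says the series, first, only, none or still open, it means among the compounds named here.

Compound 1 `COc1cc(C(=O)c2sc(-c3ccc(-c4ccccc4)cc3)cc2N)cc(OC)c1OC`: > 10000 nM (a limit of the assay, not a number)
Compound 2 `COc1cc(C(=O)c2sc(-c3ccc(Cl)cc3)cc2N)cc(OC)c1OC`: 77 nM

Both compounds were tested in a functional assay on MOLT-4 cells (Homo sapiens) for antiproliferative activity; a lower number here means a stronger inhibitor, a higher number a weaker inhibitor. Within the data shown here, compound 2 holds the only true number there, 77 nM. For compound 1 there is only a limit: the limit of > 10000 nM in this assay, at which 1 of the 2 values shown sits.

Compound 3 `COc1cc(C(=O)c2sc(-c3ccc(I)cc3)cc2N)cc(OC)c1OC` differs from compound 2 in a single group: iodo in place of chloro on an aromatic carbon. Among the measured compounds shown here, the only measured step at this place, an at least 120-fold lower number from compound 1 to compound 2 (2.11 log units; beyond the scatter), is large, so the group here can clearly matter. That step, however, exchanged phenyl for chloro, whereas here one heavy atom replaces another, so a much smaller change is expected. The expected step, a 1.3-fold higher number from compound 2 to compound 3 (0.11 log units; within the scatter), is estimated to stay within the scatter, with no firm direction. Compound 3 is estimated at 100 nM, with an expected range from 30 nM to 350 nM.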

Compound 3, half-maximal inhibitory concentration: 190 nM
For compound 3 the middle estimate is 1.9-fold (0.28 log units) below the measured one; the range from low to high includes it.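

In this assay, swapping one single atom for another at this place is not neutral: a 2.5-fold higher number from compound 2 to compound 3 (0.39 log units; beyond the scatter) is a modest step, yet it lies beyond the scatter, so chloro gives the lower number here. Iodo nevertheless stays far from phenyl, with an at least 52-fold lower number from compound 1 to compound 3 (1.72 log units; beyond the scatter), so the loss seen with phenyl does not come with every replacement of chloro. That step is only a bound, as compound 1 carries a limit of the assay and not a number: the limit of > 10000 nM in this assay, at which 1 of the 3 values shown sits.

The compounds shown leave open how fluoro, bromo, a methyl group or an amine would fare at this place, and whether any of them would match chloro. They also do not tell why iodo and phenyl give higher numbers than chloro.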